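The source may report more compounds than this note shows. Statements on the series, on what has been measured and on what is new or still open speak of the compounds shown alone.

In a functional assay on HepG2 cells (Homo sapiens) for cytotoxicity, read by MTT assay, with a stated time of 24 h (a higher number here means a weaker inhibitor, a lower number a stronger inhibitor), compound 2 (`O=C1/C(=C/c2cccnc2)CN(S(=O)(=O)c2ccc(C(F)(F)F)cc2)C/C1=C\c1ccccc1C(F)(F)F`) gives 1710 nM, the lowest of the three numbers, while compound 3 (`O=C1/C(=C/c2cccnc2)CN(S(=O)(=O)c2ccc(Cl)cc2)C/C1=C\c1ccccc1C(F)(F)F`) gives 3620 nM and compound 1 (`O=C1/C(=C/c2cccnc2)CN(S(=O)(=O)c2ccc([N+](=O)[O-])cc2)C/C1=C\c1ccccc1C(F)(F)F`) gives 9370 nM. Compound 4 (`O=C1/C(=C/c2ccncc2)CN(S(=O)(=O)c2ccc(C(F)(F)F)cc2)C/C1=C\c1ccccc1C(F)(F)F`) keeps the trifluoromethyl of compound 2 and carries pyridin-4-yl in place of pyridin-3-yl on a double-bonded chain carbon bound to a double-bonded ring carbon. For the measured compounds named here, no measured step touches that place. The steps of a 2.1-fold higher number from compound 2 to compound 3 (0.33 log units; beyond the scatter) and a 5.5-fold lower number from compound 1 to compound 2 (0.74 log units; beyond the scatter) arise from a different exchange and serve only as a gauge of size. No direction can be drawn from them, so no step beyond the scatter is expected in this assay. The estimated change is a 1.1-fold higher number from compound 2 to compound 4 (0.02 log units; within the scatter). For compound 4 the expected value is 1800 nM, with an estimated range of 700 nM to 4500 nM.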

Compound 4, half-maximal inhibitory concentration: 3240 nM
Estimate against measurement, compound 4: 1.8-fold (0.26 log units) below; the range from low to high includes it.
By their numbers in this assay, from the lowest: compounds 2, 4 and 3 (each within the scatter of the next, the first and the last beyond it); then compound 1.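

The exchange of pyridin-3-yl for pyridin-4-yl on a double-bonded chain carbon bound to a double-bonded ring carbon gives, in this assay, a 1.9-fold higher number from compound 2 to compound 4 (0.28 log units; within the scatter), the only step shown at this place. With the trifluoromethyl held fixed, the two pyridine groups cannot be told apart here, unlike the exchanges on the aromatic carbon, which all lie beyond the scatter. No evidence is available that bears on this result.

From the compounds shown here alone, whether phenyl or pyridin-2-yl at this place would give a step beyond the scatter remains open. So does whether the same pyridine exchange would stay within the scatter with chloro or nitro in place of the trifluoromethyl.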